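The source may report more compounds than this note shows. Statements on the series, on what has been measured and on what is new or still open speak of the compounds shown alone.

For the measured compounds named here, compound 2 `Oc1cc(C(F)(F)F)ccc1-c1nc(-c2ccccc2O)n(-c2ccc(F)cc2F)n1` is one of two compounds measured in a functional assay on PC-12 cells (Rattus norvegicus) for cytotoxicity, read by MTT assay, with stated times of 2 h and 24 h, tested at 5 uM (a lower number here means a weaker effect, a higher number a stronger effect of the compound at the concentration tested), where compound 2 gives 83.5%. Going by the values given here, its only neighbour is compound 1 `Oc1cc(C(F)(F)F)ccc1-c1nc(-c2ccccc2O)n(-c2ccc(OC(F)(F)F)cc2)n1`, and in this assay compound 1 gives 84.9%; the step of a number 1.4 percentage points lower from compound 1 to compound 2 (within the scatter) lies within the scatter, so the two numbers cannot be told apart, even though the figure of compound 2 is the smaller of the pair.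

Compound 3 `Cc1cc(C)cc(-n2nc(-c3ccc(C(F)(F)F)cc3O)nc2-c2ccccc2O)c1` has not yet been measured. It differs from compound 2 by 3,5-dimethylphenyl in place of 2,4-difluorophenyl on an aromatic nitrogen. Among the compounds with values here, the one measured step that bears on this change is a number 1.4 percentage points lower from compound 1 to compound 2 (within the scatter), which also exchanged the group on the aromatic nitrogen and produced no movement beyond the scatter. Within the data shown here, with only that step to go on, the account expects the exchange for 3,5-dimethylphenyl to behave in the same way, and the step of a number 0.5 percentage points lower from compound 2 to compound 3 (within the scatter) is therefore estimated to stay within the scatter. On that basis compound 3 is expected to give about 83% in this assay, with a range from 70% to 92%.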

Compound 3, a percentage reported as activity, at one concentration (the size of the read-out at that concentration, not a potency): 102%
Estimate against measurement, compound 3: 19 percentage points below, and the stated range ends below it.
By their numbers in this assay, from the lowest: compounds 2 and 1 (each within the scatter of the next); then compound 3.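

At this position on the aromatic nitrogen, the group does matter in this assay: the exchange of 2,4-difluorophenyl for 3,5-dimethylphenyl gives a number 18.5 percentage points higher from compound 2 to compound 3 (beyond the scatter), and the exchange of 4-(trifluoromethoxy)phenyl for the same group gives a number 17.1 percentage points higher from compound 1 to compound 3 (beyond the scatter). The earlier pair, whose two groups both carry fluorine, could not be told apart and so showed no sensitivity here, whereas compound 3, with a group of eight carbon atoms and no fluorine, now stands highest of the three, clear of both neighbours. No measurement shown here accounts for this rise.

The three compounds cannot separate the effect of the two methyl groups from that of losing fluorine, since both differences come together in the one exchange and only a single fluorine-free group is shown. On these data alone, it also remains open how this read-out would respond to a plain phenyl group, to a phenyl ring bearing a methoxy group, an amine or a carboxylic acid, or to a saturated ring such as cyclohexyl on the same nitrogen.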